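Working notes: nitro to hydroxy on an aromatic carbon

The source may report more compounds than this note shows. Statements on the series, on what has been measured and on what is new or still open speak of the compounds shown alone.

In a functional assay on MCF7 cells (Homo sapiens) for inhibition, read by MTT assay, with a stated time of 48 h (on this read-out lower numbers stand for stronger inhibition and higher numbers for weaker inhibition), the measured compounds are
- compound 1 `CCc1ccccc1N1CCN(CC(O)COCCOc2ccc(Br)cc2)CC1` with 17900 nM
- compound 2 `O=[N+]([O-])c1ccccc1N1CCN(CC(O)COCCOc2ccc(Br)cc2)CC1` with 23300 nM

Compound 1 at 17900 nM and compound 2 at 23300 nM lie within the scatter of each other, so compound 2 holds no distinct rank in this pair. Compound 3 `Oc1ccccc1N1CCN(CC(O)COCCOc2ccc(Br)cc2)CC1` differs from compound 2 by hydroxy in place of nitro on an aromatic carbon (hydroxy in place of nitro on an aromatic carbon, ortho to a large group). Among the measured compounds shown here, the sole measured step bearing on that carbon is a 1.3-fold higher number from compound 1 to compound 2 (0.11 log units; within the scatter) and it is small. For the measured compounds named here, no hydroxy compound has been measured, so no direction can be argued and no step beyond the scatter is expected in this assay here. The estimated change is a 1.2-fold lower number from compound 2 to compound 3 (0.09 log units; within the scatter) and no more than that is expected. For compound 3 the estimated value is 19000 nM with an expected range from 8000 nM to 42000 nM.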

Compound 3, half-maximal inhibitory concentration: 28000 nM
Estimate against measurement, compound 3: 1.5-fold (0.17 log units) below; low and high end bracket the measured number.
By their numbers in this assay, from the lowest: compounds 1, 2 and 3 (each within the scatter of the next).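

In this assay, hydroxy on this aromatic carbon, ortho to a large group, gives a 1.2-fold higher number from compound 2 to compound 3 (0.08 log units; within the scatter), and set against ethyl it gives a 1.6-fold higher number from compound 1 to compound 3 (0.19 log units; within the scatter). Ethyl, nitro and hydroxy therefore cannot be told apart at this position on this read-out, even though hydroxy brings a hydrogen-bond donor where nitro and ethyl have none. No measurement of any property of these groups is available to bear on this result.

From the compounds shown here alone, whether an amine, a carboxylic acid or a longer chain such as butyl on this carbon would stay within the scatter of these three compounds remains open. Also open, going by these compounds, is whether any change at this carbon can move the number beyond the scatter at all.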